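The compounds below may be only part of what the source reports. "The series", "measured", "known", "first", "only" and "open" are said of these compounds alone.

Of the compounds shown here, three built on one shared core have been measured in a functional assay on MCF7 cells (Homo sapiens) for inhibition, read by MTT assay, with a stated time of 48 h; a lower number here means a stronger inhibitor, a higher number a weaker inhibitor. Compound 1 `CCC(C)NC(=O)/C=C/c1c(/C=C/c2ccc(OC)cc2)cc(OC)cc1OC` gives 3430 nM. Compound 2 `COc1ccc(/C=C/c2cc(OC)cc(OC)c2/C=C/C(=O)N2CCN(C)CC2)cc1`, with 4-methylpiperazin-1-yl in place of (sec-butyl)amino on a carbonyl carbon, gives 2290 nM, a step of a 1.5-fold lower number from compound 1 to compound 2 (0.18 log units; within the scatter). Compound 3 `COc1ccc(/C=C/c2cc(OC)cc(OC)c2/C=C/C(=O)NC(C)C)cc1` gives 2560 nM in this assay; against compound 1 the step is a 1.3-fold lower number from compound 1 to compound 3 (0.13 log units; within the scatter), and against compound 2 it is a 1.1-fold higher number from compound 2 to compound 3 (0.05 log units; within the scatter). Compound 3 thus has the second highest of the three numbers, yet every gap among them lies within the scatter, so the three cannot be ranked.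

Compound 4 `COc1ccc(/C=C/c2cc(OC)cc(OC)c2/C=C/C(=O)N2CCCC(C)C2)cc1` has not yet been measured. It differs from compound 3 in one place: 3-methylpiperidin-1-yl in place of isopropylamino on a carbonyl carbon. The measured step bearing most directly on this change is a 1.1-fold higher number from compound 2 to compound 3 (0.05 log units; within the scatter), where 4-methylpiperazin-1-yl on the same carbonyl carbon gave way to isopropylamino, and a 1.5-fold lower number from compound 1 to compound 2 (0.18 log units; within the scatter) points the same way; neither exchange at this carbonyl carbon moved the number beyond the scatter. In this assay the expected step is therefore a 1.0-fold lower number from compound 3 to compound 4 (0.01 log units; within the scatter), none beyond the scatter. Compound 4 is estimated at 2500 nM in this assay, with a range from 1200 nM to 5200 nM.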

Compound 4, half-maximal inhibitory concentration: 11900 nM
Compound 4: middle estimate off by 4.8-fold (0.68 log units), on the low side; the whole stated range lies below it.
By their numbers in this assay, from the lowest: compounds 2, 3 and 1 (each within the scatter of the next); then compound 4.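

In this assay, going by these compounds alone, the exchange at this carbonyl carbon, which had moved nothing beyond the scatter among the earlier compounds, does so for the first time when 3-methylpiperidin-1-yl replaces isopropylamino (a 4.6-fold higher number from compound 3 to compound 4 (0.67 log units; beyond the scatter)), and compound 4 also stands clear of the other two (a 5.2-fold higher number from compound 2 to compound 4 (0.72 log units; beyond the scatter); a 3.5-fold higher number from compound 1 to compound 4 (0.54 log units; beyond the scatter)), which makes it the weakest of the four. The position is therefore not indifferent to what sits on the carbonyl carbon, yet a six-membered non-aromatic ring there, or the absence of the amide hydrogen, does not alone go with the higher number, since compound 2 has both features with 4-methylpiperazin-1-yl and stays within the scatter of compound 1 and compound 3. No measurement shown here explains why 3-methylpiperidin-1-yl behaves differently from 4-methylpiperazin-1-yl.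

The compounds shown leave open whether the higher number belongs to the piperidine ring itself or to its methyl group, a question that unsubstituted piperidin-1-yl and 4-methylpiperidin-1-yl would address. They also leave open how other rings or small amines on this carbonyl carbon, such as morpholin-4-yl or dimethylamino, would compare.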